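The source may hold more compounds than are shown below. What is called first, only, known or untested is meant among the compounds shown, and "the series" means these compounds.

Measured compounds:
compound 1 `CN1CCCN(CCn2ccc3ccc(Br)cc32)CC1` — in an assay on HEK293 cells for binding affinity to 5-hydroxytryptamine receptor 7 (Homo sapiens), read by radioligand binding (on this read-out higher numbers stand for weaker inhibition and lower numbers for stronger inhibition), compound 1 gives 31 nM
compound 2 `CC(C)(C)CN1CCCN(CCn2ccc3ccc(Br)cc32)CC1` — in this assay compound 2 gives 163 nM

Compound 2 stands at the higher of the two numbers in this assay; its nearest neighbour is compound 1, reached by a 5.3-fold higher number from compound 1 to compound 2 (0.72 log units; beyond the scatter). Among the compounds with values here, that single step, tert-butyl in place of hydrogen on a saturated chain carbon bound to an amine nitrogen in a ring, is the only measured change.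

Compound 3 `Brc1ccc2ccn(CCN3CCCN(C4CCCCC4)CC3)c2c1` is not yet measured. It differs from compound 2 as follows: cyclohexyl in place of neopentyl on an amine nitrogen in a ring. Neopentyl leaves and cyclohexyl enters, a group of comparable heavy-atom count, neither carrying donors or acceptors, sitting on the same amine nitrogen in a ring of the seven-membered non-aromatic ring with 2 nitrogen.

Within the data shown here, no measured step matches this exchange; the step from compound 1 to compound 2 shows only that adding bulk at that position raised the number, not how one large group compares with another. With bulk retained, no step beyond the scatter is expected from compound 2 to compound 3 in this assay, and the estimate is a 1.5-fold lower number from compound 2 to compound 3 (0.17 log units; within the scatter). Compound 3 is therefore expected near 110 nM, within 35 nM to 350 nM.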

Compound 3, inhibition constant: 17 nM
Beside the measured number, compound 3's estimate is 6.5-fold (0.81 log units) above it; the measured number lies below the stated range.
By their numbers in this assay, from the lowest: compounds 3 and 1 (each within the scatter of the next); then compound 2.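

In this assay, cyclohexyl in place of neopentyl on the amine nitrogen in a ring gives a 9.6-fold lower number from compound 2 to compound 3 (0.98 log units; beyond the scatter), so two carbon-only groups with no hydrogen-bond donors or acceptors are clearly separated at this position, and the earlier bulk step cannot be read as a general penalty for any large group there. Cyclohexyl in place of methyl gives a 1.8-fold lower number from compound 1 to compound 3 (0.26 log units; within the scatter), so among these three compounds, the higher number belongs to compound 2 alone, and compound 3 shows that a large carbon group on this nitrogen can sit level with methyl. Nothing shown here accounts for the difference between neopentyl and cyclohexyl.

Still open, going by these compounds, is how other groups on the same nitrogen compare, such as an unbranched n-butyl chain, cyclopropyl, phenyl, or a cyclohexyl carrying a hydroxyl, which would show whether the ring itself or the branching of neopentyl tracks with the change in number. The bromine and the two-carbon link to the seven-membered ring stay the same throughout, so it is also unsettled whether the neopentyl and cyclohexyl difference persists with chlorine or methoxy in place of bromine, or with a longer chain.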